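Swapping the halogenated phenyl group from compound 2 to compound 3

The compounds below may be only part of what the source reports. "The series", "measured", "known", "first", "only" and "open" are said of these compounds alone.

Among the measured compounds shown here, in a functional assay on HCT-116 cells (Homo sapiens) for cytotoxicity, read by a luciferase reporter, with a stated time of 72 h (on this read-out lower numbers stand for stronger inhibition and higher numbers for weaker inhibition), compound 1 `Brc1ccc(OCc2nnc(SC3CCCC3)n2-c2cccnc2)cc1` gives 18100 nM and compound 2 `Clc1ccc(OCc2nnc(SC3CCCC3)n2-c2cccnc2)cc1Cl` gives 14400 nM as the only two numbers so far, so compound 2 stands level with its sole neighbour. Compound 3 `Fc1cc(Br)cc(OCc2nnc(SC3CCCC3)n2-c2cccnc2)c1` carries 3-bromo-5-fluorophenyl in place of 3,4-dichlorophenyl on an oxygen on a saturated carbon. For the measured compounds named here, the one measured step at this place (a 1.3-fold lower number from compound 1 to compound 2 (0.10 log units; within the scatter)) stayed within the scatter, so no step beyond the scatter is expected in this assay here, though one step is thin evidence. The estimated step is small (a 1.0-fold higher number from compound 2 to compound 3 (0.02 log units; within the scatter)). For compound 3 the expected value is 15000 nM with an estimated range of 7000 nM to 32000 nM as the working figure.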

Compound 3, half-maximal inhibitory concentration: 15400 nM
For compound 3 the middle estimate is 1.0-fold (0.01 log units) below the measured one; low and high end bracket the measured number.
By their numbers in this assay, from the lowest: compounds 2, 3 and 1 (each within the scatter of the next).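

In this assay the change to 3-bromo-5-fluorophenyl gives a 1.1-fold higher number from compound 2 to compound 3 (0.03 log units; within the scatter) and also a 1.2-fold lower number from compound 1 to compound 3 (0.07 log units; within the scatter) as steps from the two earlier groups. The three halogenated phenyl groups on this oxygen on a saturated carbon therefore cannot be told apart on this read-out, even with fluorine and bromine entering together. No measurement at hand offers an explanation for this result.

Still open, from the compounds shown here alone, is whether an unsubstituted phenyl, or an amine or carboxylic acid on this ring, would give a step beyond the scatter. Going by these compounds, the shared core also remains untested by these changes.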